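Removing One Piperidine from Compound 2

A few compounds are considered here, and "the series" means these few. Any claim that something is new, unique, unknown or untested is made for them only; others in the source may bear on it.

Of the compounds shown here, two have been measured so far in a physicochemical assay for acid dissociation, read by spectrophotometry. Compound 1 `Cc1cc(=O)c(O)c(CN2CCCCC2)n1C` gives 10.3. Compound 2 `O=c1cc(CN2CCCCC2)n(CCN2CCCCC2)cc1O` gives 8.95, the lower of the two numbers, and the gap between them is beyond the usual scatter.

Compound 3 `Cn1cc(O)c(=O)cc1CN1CCCCC1` has not yet been measured. It differs from compound 2 in one place: hydrogen in place of (piperidin-1-yl)methyl on a saturated chain carbon bound to an aromatic nitrogen. In words, this is hydrogen in place of (piperidin-1-yl)methyl on a saturated chain carbon bound to an aromatic nitrogen. Going by the values given here, no measured pair differs in only one place, so the data offer no direct guide to the size of this change. The expected change in this assay is a small rise, slightly beyond the scatter: a number 0.35 log units higher from compound 2 to compound 3 (beyond the scatter). Compound 3 is estimated at 9.3, with an expected range from 8.8 to 9.9.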

Compound 3, acid dissociation constant: 8.86
The estimate for compound 3 lay 0.44 log units above the measured number, and the stated range covers the measured number.
By their numbers in this assay, from the lowest: compounds 3 and 2 (each within the scatter of the next); then compound 1.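

In this assay, going by these compounds alone, there is now a first comparison of two compounds that differ in only one place: hydrogen in place of (piperidin-1-yl)methyl on a saturated chain carbon bound to an aromatic nitrogen gives a number 0.09 log units lower from compound 2 to compound 3 (within the scatter). At this place, then, the 7 heavy atoms of the (piperidin-1-yl)methyl group, with its six-membered non-aromatic ring, can be absent while compound 2 and compound 3 remain indistinguishable in their acid dissociation constants. Nothing available explains this result.

A single pair cannot show whether another group at this place, such as a carboxylic acid, an amine or a longer chain, would also stay within the scatter of compound 3. It also leaves open whether the same change would give a similar result on a different core.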